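Phenyl to Sec-Butyl on a Weakly Inhibiting Cyclic Core

This account rests on a few compounds, and the source may have more. Where it says the series, first, only, none or still open, it means among the compounds named here.

Measured compounds:
compound 1 `O=C1NC(c2ccccc2)C(=O)N1C1CCCC1`: 22000 nM
compound 2 `CCC(C)C(NC(=O)NO)C(=O)NC1CCCC1`: > 100000 nM

Two measured compounds are shown. Among the compounds with values here, in a functional assay on MCF7 cells (Homo sapiens) for inhibition (on this read-out higher numbers stand for weaker inhibition and lower numbers for stronger inhibition), compound 1 gives 22000 nM and is the only compound with a numeric value in this assay. Compound 2 in this assay reaches only > 100000 nM, which is a limit of the assay rather than a number, (the limit of > 100000 nM in this assay, at which 1 of the 2 values shown sits). Compound 3 `CCC(C)C1NC(=O)N(C2CCCC2)C1=O` has not yet been measured. It differs from compound 1 in one place: sec-butyl in place of phenyl on a saturated ring carbon. Within the data shown here, no measured pair of compounds differing in one place exists here, so the size of this change has no precedent in these data. Since compound 1 gives only 22000 nM in this assay, the step of a 2.3-fold higher number from compound 1 to compound 3 (0.36 log units; beyond the scatter) is expected to lean toward weaker inhibition, possibly beyond the scatter. Compound 3 is therefore estimated at 50000 nM, in a range from 15000 nM to 150000 nM.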

Compound 3, half-maximal inhibitory concentration: 67400 nM
Beside the measured number, compound 3's estimate is 1.3-fold (0.13 log units) below it; the range from low to high includes it.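

Within the data shown here, the first step at this position shows that the read-out responds to what sits on the saturated ring carbon of the shared core. In this assay the exchange of phenyl for sec-butyl gives a 3.1-fold higher number from compound 1 to compound 3 (0.49 log units; beyond the scatter) and so moves toward weaker inhibition, a modest change that is beyond the scatter. Of these two groups, phenyl therefore gives the stronger inhibition here, but no information shown accounts for the step.

The compounds shown leave open whether the aromatic ring itself matters or whether any ring at this carbon would serve, a question that cyclohexyl or benzyl in the same place would address. They also do not show how an amine or a carboxylic acid would behave on this carbon.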